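A few compounds are considered here, and "the series" means these few. Any claim that something is new, unique, unknown or untested is made for them only; others in the source may bear on it.

Measured in an assay for inhibition of Indoleamine 2,3-dioxygenase 1 (Homo sapiens), with stated times of 10 min and 60 min, tested at 10 uM; a higher number here means a stronger effect of the compound at the concentration tested, a lower number a weaker effect:
Compound 1 `O=[N+]([O-])c1ccccc1CNc1cc(Br)cc2[nH]ncc12`: 67%
Compound 2 `N#Cc1cc(NCc2ccccc2[N+](=O)[O-])c2cn[nH]c2c1`: 7%
Compound 3 `FC(F)(F)c1cc(NCc2cccc(Br)c2)c2cn[nH]c2c1`: 23%

Compound 2 stands lowest of the three in this assay, below compound 3 and far below compound 1. For the measured compounds named here, the one single-point step among them, a number 60 percentage points lower from compound 1 to compound 2 (beyond the scatter), shows how much ground the cyano compound has lost against the bromo compound. Compound 4 `COC(=O)c1cc(NCc2ccccc2[N+](=O)[O-])c2cn[nH]c2c1` differs from compound 2 in one place: methoxycarbonyl in place of cyano on an aromatic carbon. Going by the values given here, no measured step exchanges a cyano for a methoxycarbonyl, so the direction is uncertain; the account rests only on compound 2 being the lowest. A modest recovery is expected, a number 15 percentage points higher from compound 2 to compound 4 (beyond the scatter), short of compound 1. Compound 4 is therefore estimated at 22%, with a range from 2% to 50%.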

Compound 4, a percentage reported as inhibition, at one concentration (the size of the read-out at that concentration, not a potency): 11%
Compound 4: the middle estimate sits 11 percentage points above what was measured; the range from low to high includes it.
By their numbers in this assay, from the lowest: compounds 2 and 4 (each within the scatter of the next); then compound 3; then compound 1.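

Methoxycarbonyl is the second group on this aromatic carbon to give a large loss against bromo, a number 56 percentage points lower from compound 1 to compound 4 (beyond the scatter), so that loss is not peculiar to cyano. Cyano and methoxycarbonyl cannot be told apart in this assay, a number 4 percentage points higher from compound 2 to compound 4 (within the scatter), although they differ in heavy atoms and hydrogen-bond acceptors. No available evidence bears on this result. The compounds shown leave open whether chloro, an amine or a carboxylic acid on this carbon would stand with bromo or with these two groups. They also leave open whether bromo keeps its lead with other groups on the benzyl ring.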